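The source may report more compounds than this note shows. Statements on the series, on what has been measured and on what is new or still open speak of the compounds shown alone.

Measured in an assay on CHO cells for binding affinity to Substance-P receptor (Homo sapiens); a higher number here means a weaker inhibitor, a lower number a stronger inhibitor:

Compound 1 `CCCCCN(CCCCC)C(=O)N1CCN(C(=O)N(c2ccccc2)c2ccccc2)[C@H](C(=O)NCC(=O)O)C1` gives 597 nM.
Compound 2 `CCCCCN(CCCCC)C(=O)N1CCN(C(=O)N(c2ccccc2)c2ccccc2)[C@H](C(=O)N(C)CCN(C)Cc2ccccc2)C1` gives 290 nM.
Compound 3 `CCCCCN(CCCCC)C(=O)N1CCN(C(=O)N(c2ccccc2)c2ccccc2)[C@H](C(=O)N(C)CCN(C)Cc2cc(C)cc(C)c2)C1` gives 200 nM.

Compound 1 stands highest of the three numbers in this assay; compound 2 is nearest to it and compound 3 furthest, both beyond the scatter. Compound 4 `CCCCCN(CCCCC)C(=O)N1CCN(C(=O)N(c2ccccc2)c2ccccc2)[C@H](C(=O)NCCNCc2ccccc2OC)C1` arises from compound 1 by the change (((2-methoxybenzyl)amino)methyl in place of carboxy on a saturated chain carbon bound to an amide-type nitrogen). Among the measured compounds shown here, no measured step covers exactly this exchange. For the measured compounds named here, the only step within the set, a 1.5-fold lower number from compound 2 to compound 3 (0.16 log units; within the scatter), concerns a substitution on the benzyl ring and lies within the scatter, so it says little about compound 4. What bears on it instead is the comparison of compound 1 with compounds 2 and 3: both carry an amine-bearing chain with a benzyl group in place of the carboxy end, and both give clearly lower numbers than compound 1. Compound 4 carries a related chain and is therefore expected to show a drop of similar size, a 2.4-fold lower number from compound 1 to compound 4 (0.38 log units; beyond the scatter), in this assay. The estimate for compound 4 is 250 nM, with a range from 100 nM to 650 nM.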

Compound 4, half-maximal inhibitory concentration: 9 nM
Compound 4: the middle estimate sits 28-fold (1.44 log units) above what was measured; measured number outside the range, below it.
By their numbers in this assay, from the lowest: compound 4; then compounds 3 and 2 (each within the scatter of the next); then compound 1.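

In this assay, putting ((2-methoxybenzyl)amino)methyl in place of carboxy on a saturated chain carbon bound to an amide-type nitrogen gives a 66-fold lower number from compound 1 to compound 4 (1.82 log units; beyond the scatter), a large step. Among the compounds shown here, the only one-place step among the earlier compounds, a 1.5-fold lower number from compound 2 to compound 3 (0.16 log units; within the scatter), lay within the scatter, so this is the first sign in the set that a single exchange can shift the number substantially, and here the exchange is at the carboxy end of the chain. No available data explain the size of this step.

The amine nitrogen, the benzene ring and the methoxy group all enter together, so the compounds shown leave open how much of the step belongs to each. They also leave open how a longer chain, or a chlorine or hydroxy group in place of the methoxy, would read in this assay.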